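Working notes: from compound 1 to compound 3

This account rests on a few compounds, and the source may have more. Where it says the series, first, only, none or still open, it means among the compounds named here.

Going by the values given here, compound 1 `N=C(N)NCCC[C@H](NC(=O)CN(c1nc(Cl)nc2[nH]cnc12)C1CC1)C(=O)O` is the stronger of the two measured members of this pair; in a functional assay on the whole organism (Tail, strain ICR) with Mus musculus as the target, in the tail flick test, with a stated time of 30 min, at a dose of 25 umol/kg by the oral route (a lower number here means a weaker effect, a higher number a stronger effect of the compound at the dose given), compound 1 gives 45.4%, the highest of the two numbers. Among the compounds with values here, compound 2 `N=C(N)NCCC[C@H](NC(=O)CN(c1nc(Cl)nc2[nH]cnc12)C1CC1)C(=O)OCc1ccccc1` gives 23.2%, and the only measured step, a number 22.2 percentage points lower from compound 1 to compound 2 (beyond the scatter), comes from putting benzyl in place of hydrogen on an oxygen next to a carbonyl group. Compound 3 `NC(=O)C[C@H](NC(=O)CN(c1nc(Cl)nc2[nH]cnc12)C1CC1)C(=O)O` changes a different part of compound 1: a group of 3 heavy atoms (1 carbon, 1 nitrogen, 1 oxygen; no ring) in place of a group of 6 heavy atoms (3 carbon, 3 nitrogen; no ring), on a saturated chain carbon, two bonds along the chain from an amide-type nitrogen and a carbonyl carbon. Within the data shown here, no measured step touches this chain carbon, so the step from compound 1 to compound 2 offers no direct guide, only a sign that single changes can move the read-out beyond the scatter. A step of uncertain direction, most likely a modest loss, is therefore expected, a number 15.4 percentage points lower from compound 1 to compound 3 (beyond the scatter). Compound 3 is estimated at 30%, within 5% to 60%.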

Compound 3, a percentage reported as activity, at one dose (the size of the read-out at that dose, not a potency): 29.7%
Beside the measured number, compound 3's estimate is 0.3 percentage points above it; measured number inside the range.
By their numbers in this assay, from the lowest: compounds 2 and 3 (each within the scatter of the next); then compound 1.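

In this assay, the saturated chain carbon, two bonds along the chain from an amide-type nitrogen and a carbonyl carbon, is now shown to be a second place where a single change moves the read-out: carbamoyl in place of the group of 6 heavy atoms gives a number 15.7 percentage points lower from compound 1 to compound 3 (beyond the scatter) with the free acid kept. The read-out is not lost with the larger group gone, since compound 3 still gives 29.7% at the dose used. Nothing at hand bears on what lies behind this step.

The compounds shown do not separate the size of the group at this position from the identity of its end group. An amine on a chain of the same length, or a longer chain ending in carbamoyl, would bear on that question.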